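This account rests on a few compounds, and the source may have more. Where it says the series, first, only, none or still open, it means among the compounds named here.

Compound 3 `CNc1ncnc2c1c(I)cn2[C@@H]1O[C@H](CO)[C@@H](O)[C@H]1O` is a nucleoside carrying a methylamino group and an iodine on its core. In a functional assay on CEM-DNR-bulk cells (Homo sapiens), read by MTT assay, with a stated time of 72 h (a lower number here means a stronger inhibitor, a higher number a weaker inhibitor), compound 3 gives > 20000 nM, which is a limit of the assay and not a number.

Compound 4 `Cc1ncnc2c1c(I)cn2[C@@H]1O[C@H](CO)[C@@H](O)[C@H]1O` keeps the iodine and differs in one place: methyl in place of methylamino on an aromatic carbon, with methyl in place of methylamino on an aromatic carbon.

For the measured compounds named here, no measured step makes this exact swap, so the evidence is indirect. Compound 1 `Cc1ncnc2c1c(-c1ccsc1)cn2[C@@H]1O[C@H](CO)[C@@H](O)[C@H]1O` and compound 2 `C#Cc1cn([C@@H]2O[C@H](CO)[C@@H](O)[C@H]2O)c2ncnc(C)c12` already carry the methyl group that compound 4 gains. In this assay compound 1 gives 8560 nM and compound 2 gives 160 nM, so both give real numbers.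

Going by the values given here, the one measured step, a 54-fold lower number from compound 1 to compound 2 (1.73 log units; beyond the scatter), comes from ethynyl in place of thiophen-3-yl. It changes a different group from the one changing here, but it shows that the group iodine occupies in compound 4 can shift the result strongly. That makes the outcome for compound 4 hard to pin down, and a wide range is needed.

A lower number than that of compound 3 is therefore expected in this assay, and the change is likely to lie beyond the scatter. The expected change is an at least 13-fold lower number from compound 3 to compound 4 (1.12 log units; beyond the scatter). For compound 4 the estimated value is 1500 nM, with an expected range from 150 nM to 15000 nM.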

Compound 4, half-maximal inhibitory concentration: 12600 nM
Compound 4: the middle estimate sits 8.4-fold (0.92 log units) below what was measured; the measured number falls inside the stated range.
By their numbers in this assay, from the lowest: compound 2; then compounds 1 and 4 (each within the scatter of the next). At a limit, above all of these: compound 3.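

The swap to methyl in place of methylamino reads only as an at least 1.5-fold lower number from compound 3 to compound 4 (0.20 log units; that floor lies within the scatter), so the true change could be small or much larger, because the value of compound 3 is a limit of the assay: the limit of > 20000 nM in this assay, at which 1 of the 4 values shown sits.

The other two new steps add a third group to the comparison at the carbon that holds iodo in compound 4, with methyl kept in all three compounds: iodo in place of ethynyl gives a 79-fold higher number from compound 2 to compound 4 (1.90 log units; beyond the scatter), while iodo in place of thiophen-3-yl gives a 1.5-fold higher number from compound 1 to compound 4 (0.17 log units; within the scatter). Among these three compounds, then, only the ethynyl compound stands apart in this assay, and the iodo and thiophen-3-yl compounds cannot be told apart, although the earlier step alone could not show where iodo would fall.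

The compounds shown carry methylamino only together with iodo, so it remains open whether the methylamino group would give a similar result alongside ethynyl. Also open, going by these compounds, is how a plain amine or an ethyl group would compare with methyl on the same carbon, and how a nitrile would compare with ethynyl and iodo.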